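The source may report more compounds than this note shows. Statements on the series, on what has been measured and on what is new or still open speak of the compounds shown alone.

In a functional assay on A549 cells (Homo sapiens) for inhibition, read by MTT assay, with a stated time of 48 h (a lower number here means a stronger inhibitor of growth, a higher number a weaker inhibitor of growth), compound 1 (`Cn1cc(C2CC(c3ccccc3)=NN2C(=O)c2cccnc2)c2ccccc21`) reaches only a limit of the assay, > 10000 nM. Among the measured compounds shown here, compound 2 (`COc1ccc(C(=O)N2N=C(c3ccccc3)CC2c2cn(C)c3ccccc23)cn1`) gives 3040 nM, the only actual number available so far. Compound 3 (`COc1ccc2c(c1)c(C1CC(c3ccccc3)=NN1C(=O)c1ccc(OC)nc1)cn2C`) keeps everything in compound 2 except for one exchange, methoxy in place of hydrogen on an aromatic carbon, on a six-membered aromatic ring of carbon only, part of a fused or bridged system of two rings. For the measured compounds named here, one measured step bears on this, the same exchange made at another place in the molecule: an at least 3.2-fold lower number from compound 1 to compound 2 (0.51 log units; beyond the scatter). That single step lies beyond the scatter, so a modest further fall in the number is expected in this assay, though this rests on thin evidence. The expected change is a 1.9-fold lower number from compound 2 to compound 3 (0.28 log units; within the scatter). For compound 3, the estimated value is 1600 nM, within an expected range of 450 nM to 6000 nM.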

Compound 3, concentration for 50% growth inhibition: 1110 nM
The estimate for compound 3 lay 1.4-fold (0.16 log units) above the measured number; the measured number falls inside the stated range.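

In this assay, methoxy in place of hydrogen on an aromatic carbon of the six-membered aromatic ring of carbon only lowers the number: a 2.7-fold lower number from compound 2 to compound 3 (0.44 log units; beyond the scatter). Among the compounds shown here, this is the first step here measured between two actual numbers, and it shows that the same exchange also lowers the number at this second place in the molecule. The size of the earlier step remains unknown, as it starts from compound 1, which reaches only a limit: the limit of > 10000 nM in this assay, at which 1 of the 3 values shown sits.

From the compounds shown here alone, whether an amine, a hydroxyl or a longer chain such as ethoxy at this position would lower the number further stays open. Also open is whether the fall depends on the other methoxy, since the compounds shown carry methoxy at this position only together with it.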